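Series notes: ketone aryl exchange from compound 2 to compound 4

This account rests on a few compounds, and the source may have more. Where it says the series, first, only, none or still open, it means among the compounds named here.

In a functional assay on DLA cells (Mus musculus) for cytotoxicity, read by MTT assay, with a stated time of 48 h (on this read-out lower numbers stand for stronger inhibition and higher numbers for weaker inhibition), compound 1 `Cc1ccc(C(=O)c2ccc(OCC(=O)Nc3nc(-c4ccccc4)cs3)c(C)c2)cc1` gives 26400 nM, compound 2 `COc1ccc(-c2csc(NC(=O)COc3ccc(C(=O)c4ccc(C)cc4)cc3C)n2)cc1` gives 17200 nM, and compound 3 `O=C(COc1ccc(C(=O)c2ccccc2)cc1Br)Nc1nc(-c2ccccc2)cs1` gives 43100 nM. Compound 2 has the lowest of the three numbers; compound 1 stands within the scatter of it, and only compound 3 sits beyond it. Going by the values given here, the one measured step, a 1.5-fold lower number from compound 1 to compound 2 (0.19 log units; within the scatter), concerns a methoxy on an aromatic carbon and does not touch the group on the carbonyl carbon. Compound 4 `COc1ccc(-c2csc(NC(=O)COc3ccc(C(=O)c4cccc(F)c4)cc3C)n2)cc1` differs from compound 2 by 3-fluorophenyl in place of 4-methylphenyl on a carbonyl carbon. Among the compounds with values here, no measured step bears on this exchange, so the expectation rests on the unchanged remainder: no step beyond the scatter is expected, a 1.0-fold higher number from compound 2 to compound 4 (0.02 log units; within the scatter). Compound 4 is therefore estimated at 18000 nM in this assay, between 8000 nM and 40000 nM.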

Compound 4, half-maximal inhibitory concentration: 28400 nM
Compound 4: the middle estimate sits 1.6-fold (0.20 log units) below what was measured; the range from low to high includes it.
By their numbers in this assay, from the lowest: compounds 2, 1, 4 and 3 (each within the scatter of the next, the first and the last beyond it).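

In this assay, going by these compounds alone, this is the first exchange read on the carbonyl carbon: 3-fluorophenyl in place of 4-methylphenyl gives a 1.7-fold higher number from compound 2 to compound 4 (0.22 log units; within the scatter). For this pair, the aryl group on the carbonyl carbon can therefore change without a step beyond the scatter. A single pair cannot separate the loss of the methyl from the entry of the fluorine.

As far as these compounds go, whether a carboxylic acid or an amine on that phenyl would also stay within the scatter remains open. Nothing available gives a reason for this step.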